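A few compounds are considered here, and "the series" means these few. Any claim that something is new, unique, unknown or untested is made for them only; others in the source may bear on it.

In an assay on HEK293 cells for displacement of a labelled ligand from 5-hydroxytryptamine receptor 7 (Homo sapiens) (on this read-out higher numbers stand for weaker inhibition and lower numbers for stronger inhibition), compound 1 `O=C1c2ccccc2S(=O)(=O)N1CCCCCN1CCN(c2ccc(Cl)cc2)CC1` gives 191 nM. Compound 3 `COc1ccccc1N1CCN(CCCCCCN2C(=O)c3ccccc3S2(=O)=O)CC1` gives 105 nM, within the scatter of compound 1, while compound 2 `O=C1c2ccccc2S(=O)(=O)N1CCCCCCN1CCN(c2ncccn2)CC1` gives 2520 nM, the highest of the three. Among the compounds with values here, the only measured step at the amine nitrogen in a ring is a 24-fold lower number from compound 2 to compound 3 (1.38 log units; beyond the scatter), showing that a change of the group on that nitrogen can move the number strongly. Compound 4 `O=C1c2ccccc2S(=O)(=O)N1CCCCCN1CCN(c2cccc(C(F)(F)F)c2)CC1` differs from compound 1 by 3-(trifluoromethyl)phenyl in place of 4-chlorophenyl on an amine nitrogen in a ring. That measured step concerns a swap of ring type rather than of a substituent on a phenyl ring, so it offers only an indirect guide; a substituent change of this kind is expected to move the number little, within the scatter. Compound 4 is therefore expected to give about 200 nM, in a range of 60 nM to 700 nM, which would be a 1.0-fold higher number from compound 1 to compound 4 (0.02 log units; within the scatter).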

Compound 4, inhibition constant: 35 nM
Estimate against measurement, compound 4: 5.7-fold (0.76 log units) above; the whole stated range lies above it.
By their numbers in this assay, from the lowest: compound 4; then compounds 3 and 1 (each within the scatter of the next); then compound 2.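

In this assay, the change on the amine nitrogen in a ring gives a 5.5-fold lower number from compound 1 to compound 4 (0.74 log units; beyond the scatter). So an exchange between two substituted phenyl groups at this position, and not only a swap of ring type, can move the number beyond the scatter. Nothing available explains this difference.

Compounds 1 and 4 differ in both the substituent and where it sits on the phenyl ring, so it remains open which of the two accounts for the lower number. A 3-chlorophenyl group on that nitrogen would separate them.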